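Swapping Methyl for Trifluoromethyl on an Aromatic Carbon

The source may hold more compounds than are shown below. What is called first, only, known or untested is meant among the compounds shown, and "the series" means these compounds.

Compound 1 `COc1cc2c(Oc3ccc(NC(=O)c4nn(-c5ccccc5)c(=O)cc4C)cc3F)ccnc2cc1OCCCN1CCCC1`: 120 nM
Compound 2 `COc1cc2c(Oc3ccc(NC(=O)c4nn(-c5ccccc5C)c(=O)cc4C)cc3F)ccnc2cc1OCCCN1CCCC1`: 760 nM

Both were tested in a functional assay on MKN-45 cells (Homo sapiens) for inhibition, read by MTT assay, with a stated time of 72 h; a higher number here means a weaker inhibitor, a lower number a stronger inhibitor. Going by the values given here, compound 2 stands highest of the two numbers; the only measured step, a 6.3-fold higher number from compound 1 to compound 2 (0.80 log units; beyond the scatter), came from a methyl in place of hydrogen on an aromatic carbon. Compound 3 `COc1cc2c(Oc3ccc(NC(=O)c4nn(-c5ccccc5C(F)(F)F)c(=O)cc4C)cc3F)ccnc2cc1OCCCN1CCCC1` differs from compound 2 by trifluoromethyl in place of methyl on an aromatic carbon. Among the compounds with values here, no measured step tests a trifluoromethyl, so only the direction at this carbon is known. Because a 6.3-fold higher number from compound 1 to compound 2 (0.80 log units; beyond the scatter) weakened inhibition, a further modest weakening or no change beyond the scatter is expected, giving a 2.0-fold higher number from compound 2 to compound 3 (0.30 log units; within the scatter). Compound 3 is estimated at 1500 nM, between 400 nM and 6000 nM.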

Compound 3, half-maximal inhibitory concentration: 100 nM
Estimate against measurement, compound 3: 15-fold (1.18 log units) above, and the stated range ends above it.
By their numbers in this assay, from the lowest: compounds 3 and 1 (each within the scatter of the next); then compound 2.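

In this assay, the loss seen with methyl at this aromatic carbon does not extend to every group placed there: trifluoromethyl in place of methyl gives a 7.6-fold lower number from compound 2 to compound 3 (0.88 log units; beyond the scatter). Trifluoromethyl in place of hydrogen gives a 1.2-fold lower number from compound 1 to compound 3 (0.08 log units; within the scatter), which lies within the scatter, so these two compounds cannot be told apart here. No measured evidence explains why methyl and trifluoromethyl part so sharply at this carbon.

Going by these compounds, whether a chlorine atom, a methoxy group or an amine here would track methyl or trifluoromethyl remains open. So does whether trifluoromethyl would give the same result on another carbon of this ring.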